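A few compounds are considered here, and "the series" means these few. Any claim that something is new, unique, unknown or untested is made for them only; others in the source may bear on it.

Measured compounds:
- compound 1, `CCCSc1cc(C)c(C(=O)N=C(N)N)cc1S(C)(=O)=O`: 6.8 nM
- compound 2, `Cc1cc(Nc2cccc(Cl)c2)c(S(C)(=O)=O)cc1C(=O)N=C(N)N`: 33 nM

The set so far holds two compounds, both tested in a functional assay for inhibition of sodium/hydrogen exchanger (Oryctolagus cuniculus); a higher number here means a weaker inhibitor, a lower number a stronger inhibitor. Compound 1 gives 6.8 nM and compound 2 gives 33 nM, so compound 2 stands at the higher of the two numbers, a step of a 4.9-fold higher number from compound 1 to compound 2 (0.69 log units; beyond the scatter) setting it apart from compound 1.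

The next compound, compound 3, `Cc1cc(Oc2cccnc2)c(S(C)(=O)=O)cc1C(=O)N=C(N)N`, is not yet measured. Against compound 2 it carries one change: (pyridin-3-yl)oxy in place of (3-chlorophenyl)amino on an aromatic carbon. Within the data shown here, no measured pair shows this exchange. Among the measured compounds shown here, the only step known, a 4.9-fold higher number from compound 1 to compound 2 (0.69 log units; beyond the scatter), replaced a chain with an aromatic amine at this same position and went beyond the scatter, but it says nothing direct about swapping one aromatic group for another bearing an oxygen and a ring nitrogen in place of the amine nitrogen and chlorine. Any expectation therefore rests on little, and the step is expected to be small, plausibly within the scatter, if anything toward a slightly higher number, amounting to a 1.4-fold higher number from compound 2 to compound 3 (0.13 log units; within the scatter). Compound 3 is estimated at 45 nM, with a range from 15 nM to 150 nM.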

Compound 3, half-maximal inhibitory concentration: 8.8 nM
Estimate against measurement, compound 3: 5.1-fold (0.71 log units) above, outside the stated range (below it).
By their numbers in this assay, from the lowest: compounds 1 and 3 (each within the scatter of the next); then compound 2.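

In this assay, putting (pyridin-3-yl)oxy in place of (3-chlorophenyl)amino on this aromatic carbon gives a 3.8-fold lower number from compound 2 to compound 3 (0.57 log units; beyond the scatter), so the higher number of compound 2 does not extend to every aromatic group attached here. Against the propylsulfanyl group of compound 1, the same group gives a 1.3-fold higher number from compound 1 to compound 3 (0.11 log units; within the scatter), which shows that a chain and a ring joined through oxygen can sit at this place, ortho to the methylsulfonyl group, with no difference that stands out from the scatter. No measurement on these compounds speaks to what lies behind either step.

The change from compound 2 to compound 3 alters the linking atom and the ring together, and the compounds shown cannot tell which of the two goes with the step. A (3-chlorophenyl)oxy or a (pyridin-3-yl)amino group at the same carbon would separate them, while a phenylsulfanyl group would show whether a ring joined through sulfur belongs with compound 2 or with compounds 1 and 3.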